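Acid side chain variation at one place on the shared core

The source may hold more compounds than are shown below. What is called first, only, known or untested is meant among the compounds shown, and "the series" means these compounds.

In a functional assay on CHO cells for agonist activity at Free fatty acid receptor 1 (Homo sapiens), read by a luciferase reporter (on this read-out lower numbers stand for smaller maximal responses and higher numbers for larger maximal responses), compound 2 `O=C(O)COc1ccc(NCc2cccc(Oc3ccccc3)c2)cc1` gives 84%, alongside compound 1 `O=C(O)c1ccc(NCc2cccc(Oc3ccccc3)c2)cc1`, which gives 86%, within the scatter of each other. Compound 3 `O=C(O)[C@H]1C[C@@H]1c1ccc(NCc2cccc(Oc3ccccc3)c2)cc1` gives 88%; 72% (2 entries), and its repeat spread, (the several entries of compound 3 in this assay, 88%; 72% (2 entries)), shows how far two readings of one compound can lie apart here. Going by the values given here, the only measured step at this place is a number 2 percentage points lower from compound 1 to compound 2 (within the scatter). The change to compound 4 `CC(CC(=O)O)c1ccc(NCc2cccc(Oc3ccccc3)c2)cc1` is a different swap at the same place: 1-(carboxymethyl)ethyl in place of carboxymethoxy on an aromatic carbon. Among the compounds with values here, with the one measured step inside the scatter and the repeat spread of compound 3 of similar size, no movement beyond the scatter is expected in this assay. Compound 4 is expected to give 84%, ranging from 68% to 96%. The expected step is no change at the digits printed from compound 2 to compound 4 (within the scatter).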

Compound 4, largest response reached (reported as percent of maximum), in percent of the reference or control that the assay uses: 83%
Compound 4: the middle estimate sits 1 percentage points above what was measured; the measured number falls inside the stated range.
By their numbers in this assay, from the lowest: compounds 4, 2 and 1 (each within the scatter of the next).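

At this place, on an aromatic carbon para to a large group, 1-(carboxymethyl)ethyl in place of carboxymethoxy gives a number 1 percentage points lower from compound 2 to compound 4 (within the scatter), and in place of carboxy it gives a number 3 percentage points lower from compound 1 to compound 4 (within the scatter). In this assay, the maximal response thus holds with a side chain that has no ring and no ether oxygen, so the oxygen of carboxymethoxy is not required for it. Both steps are small next to the repeat spread: the several entries of compound 3 in this assay, 88%; 72% (2 entries)

Open, going by these compounds, is whether a longer chain ending in a carboxylic acid holds the response as well. Also open, on these data alone, is whether a primary amide or a tetrazole can stand in for the carboxylic acid at this place.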